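Series notes: tolerated concentration, compounds 1 to 4

The source may report more compounds than this note shows. Statements on the series, on what has been measured and on what is new or still open speak of the compounds shown alone.

Measured so far:
- compound 1 `CCOc1ccc(/C=N/NC(=O)COc2cccc3ccccc23)cc1O`: in an ADME assay on HEL cells (Homo sapiens) for cytotoxicity (a higher number here means that more compound is tolerated, a lower number that less compound is tolerated), compound 1 gives 100 ug/mL
- compound 2 `O=C(COc1cccc2ccccc12)N/N=C/c1ccc(Cl)cc1`: in this assay compound 2 gives 100 ug/mL
- compound 3 `C/C(=N\NC(=O)COc1cccc2ccccc12)c1ccccc1`: in this assay compound 3 gives 20 ug/mL

Compound 2 stands level with compound 1 at the digits shown, the two together the highest of the three numbers and within the scatter of each other; compound 3 sits lower, beyond the scatter. Compound 4 `O=C(COc1cccc2ccccc12)N/N=C/C=C/c1ccccc1` has not yet been measured in this assay. It differs from compound 2 in one place: 2-phenylethenyl in place of 4-chlorophenyl on a carbon with a double bond to nitrogen. For the measured compounds named here, no step between measured compounds covers this change, so the direction rests on the spread seen so far. The expected step is a 1.7-fold lower number from compound 2 to compound 4 (0.22 log units; within the scatter), downward if anything and possibly none beyond the scatter. The estimate for compound 4 in this assay is 60 ug/mL, range 20 ug/mL to 120 ug/mL.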

Compound 4, minimum cytotoxic concentration: 100 ug/mL
The estimate for compound 4 lay 1.7-fold (0.22 log units) below the measured number; the range from low to high includes it.
By their numbers in this assay, from the lowest: compound 3; then compounds 1, 2 and 4 (each within the scatter of the next).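

In this assay, 2-phenylethenyl in place of 4-chlorophenyl on a carbon with a double bond to nitrogen gives no change at the digits printed from compound 2 to compound 4 (within the scatter) as the first one-place step read in this series. At this place, a change from a chlorine-bearing group to an all-carbon group with one more double bond outside aromatic rings leaves the tolerated concentration unchanged, with one six-membered aromatic ring of carbon only on both sides. No measured evidence bears on this result. Still open, as far as these compounds go, is how a group without that aromatic ring, such as a simple alkyl chain, an amine or a carboxylic acid, would read at this place.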